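The source may hold more compounds than are shown below. What is called first, only, known or untested is meant among the compounds shown, and "the series" means these compounds.

Measured so far in an assay on isolated protein (strain Charles River) for antagonist activity at histamine H2 receptor (Rattus norvegicus); on this read-out lower numbers stand for an effect already at smaller amounts and higher numbers for an effect only at larger amounts of compound:
compound 1 `Cc1cc(C)c2ccc(=O)n(CCN(C)C)c2n1` gives 3.93 ug/mL
compound 2 `CCN(CC)CCn1c(=O)ccc2c(C)cc(C)nc21` gives 1.12 ug/mL
compound 3 `Cc1cc(C)c2ccc(=O)n(CCN3CCCCC3)c2n1` gives 3.05 ug/mL

Compound 3 holds the second highest of the three numbers. Against compound 1 it shows a 1.3-fold lower number from compound 1 to compound 3 (0.11 log units; within the scatter); against compound 2 it shows a 2.7-fold higher number from compound 2 to compound 3 (0.44 log units; beyond the scatter).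

Compound 4 `Cc1cc(C)c2ccc(=O)n(CCN(C(C)C)C(C)C)c2n1` differs from compound 3 in one place: diisopropylamino in place of piperidin-1-yl on a saturated chain carbon, two bonds along the chain from an aromatic nitrogen. Within the data shown here, two measured steps bear on this. Enlarging an acyclic amine gave a 3.5-fold lower number from compound 1 to compound 2 (0.55 log units; beyond the scatter), while closing it into a ring gave a 2.7-fold higher number from compound 2 to compound 3 (0.44 log units; beyond the scatter). Compound 4 carries a larger acyclic amine, so a modest step toward lower numbers is expected in this assay. The expected step is a 1.7-fold lower number from compound 3 to compound 4 (0.23 log units; within the scatter). For compound 4 the estimated value is 1.8 ug/mL, with a range of 0.8 ug/mL to 4 ug/mL.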

Compound 4, half-maximal effective concentration: 1.44 ug/mL
The estimate for compound 4 lay 1.3-fold (0.10 log units) above the measured number, within the range that was stated.
By their numbers in this assay, from the lowest: compounds 2 and 4 (each within the scatter of the next); then compounds 3 and 1 (each within the scatter of the next).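

In this assay, diisopropylamino in place of piperidin-1-yl gives a 2.1-fold lower number from compound 3 to compound 4 (0.33 log units; beyond the scatter), and in place of dimethylamino it gives a 2.7-fold lower number from compound 1 to compound 4 (0.44 log units; beyond the scatter). In place of diethylamino it gives a 1.3-fold higher number from compound 2 to compound 4 (0.11 log units; within the scatter), so at this position the two acyclic amines with the larger alkyl groups cannot be told apart, while the piperidin-1-yl of compound 3 stands apart from both. No available measurement explains these differences. As far as these compounds go, whether pyrrolidin-1-yl, morpholin-4-yl or a longer chain to the amine would give numbers at this level remains open.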